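This account rests on a few compounds, and the source may have more. Where it says the series, first, only, none or still open, it means among the compounds named here.

Of the compounds shown here, two have been measured in a functional assay on A549 cells (Homo sapiens) for cytotoxicity, read by MTT assay, with a stated time of 48 h; on this read-out higher numbers stand for weaker inhibition and lower numbers for stronger inhibition. Compound 1 `COc1ccc(CN(C(=O)Nc2ccc(C#N)cc2)n2cnnc2)cc1OC` reaches only the limit of this assay, at > 50000 nM. Going by the values given here, compound 2 `O=C(NCc1ccccc1)N(Cc1ccccn1)n1cnnc1` is the one compound with a number, giving 22000 nM in this assay. Compound 2 thus stands as the only numbered point among the values shown. The other value shown sits at the limit of > 50000 nM in this assay, at which 1 of the 2 values shown sits. Compound 3 `O=C(Nc1ccccc1)N(Cc1ccccn1)n1cnnc1` has not yet been measured. It differs from compound 2 by phenyl in place of benzyl on an amide-type nitrogen; the benzyl on the amide-type nitrogen whose other neighbour is the carbonyl carbon gives way to phenyl. No step between measured compounds is shown, so the size of such a change is not known from this set. The step expected here is a 1.1-fold higher number from compound 2 to compound 3 (0.06 log units; within the scatter), a shift that is not expected to go beyond the scatter. Compound 3 is estimated to give 25000 nM in this assay, with a range from 8000 nM to 60000 nM.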

Compound 3, half-maximal inhibitory concentration: 24900 nM
Beside the measured number, compound 3's estimate is 1.0-fold (0.00 log units) above it, within the range that was stated.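

In this assay, going by these compounds alone, the exchange of benzyl for phenyl on the amide-type nitrogen gives the first step that can be read: a 1.1-fold higher number from compound 2 to compound 3 (0.05 log units; within the scatter). At this position, on this read-out, the two groups therefore cannot be told apart, and one size for such a change is now known. Compound 1 remains a limit and not a number, so no step to it can be read: the limit of > 50000 nM in this assay, at which 1 of the 3 values shown sits.

What the compounds shown leave open is whether this position answers to any other kind of group, such as an amine, a carboxylic acid or a longer chain in place of benzyl or phenyl. A single step also cannot tell whether the same exchange would read alike on the core of compound 1.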